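Swapping the aryl group on the alkyne of an adenosine ligand

The source may hold more compounds than are shown below. What is called first, only, known or untested is meant among the compounds shown, and "the series" means these compounds.

Compound 2 `CNC(=O)[C@@]12C[C@@H]1[C@@H](n1cnc3c(NC)nc(C#Cc4ccccc4F)nc31)[C@H](O)[C@@H]2O` gives 20% in an assay on CHO cells for displacement of a labelled ligand from adenosine receptor A1 (Homo sapiens), read by scintillation counting, with a stated time of 60 min, tested at 10 uM; on this read-out lower numbers stand for less inhibition and higher numbers for more inhibition at the one concentration tested (going by the name of the read-out). Compound 1 `CNC(=O)[C@@]12C[C@@H]1[C@@H](n1cnc3c(NC)nc(C#Cc4ccccc4)nc31)[C@H](O)[C@@H]2O` gives 18% and compound 3 `CNC(=O)[C@@]12C[C@@H]1[C@@H](n1cnc3c(NC)nc(C#Cc4ccc(OC)cc4)nc31)[C@H](O)[C@@H]2O` gives 10% in this assay, so the three numbers all lie within the scatter of one another: a number 2 percentage points higher from compound 1 to compound 2 (within the scatter) and a number 10 percentage points lower from compound 2 to compound 3 (within the scatter). Compound 4 `CNC(=O)[C@@]12C[C@@H]1[C@@H](n1cnc3c(NC)nc(C#Cc4cnn(C)c4)nc31)[C@H](O)[C@@H]2O` is not yet measured; it differs from compound 2 by 1-methyl-1H-pyrazol-4-yl in place of 2-fluorophenyl on a triple-bonded carbon. Within the data shown here, the only earlier exchange of the whole aryl group, from compound 2 to compound 3, stayed within the scatter, and no pyrazole has been measured here. Compound 4 is therefore expected to show a step of a number 5 percentage points lower from compound 2 to compound 4 (within the scatter), with an estimate of 15% and a range from 0% to 35%.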

Compound 4, a percentage reported as inhibition, at one concentration (the size of the read-out at that concentration, not a potency): 35%
For compound 4 the middle estimate is 20 percentage points below the measured one; measured number inside the range.
By their numbers in this assay, from the lowest: compounds 3, 1 and 2 (each within the scatter of the next); then compound 4.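

In this assay the group on the triple-bonded carbon can move the number beyond the scatter: phenyl, 2-fluorophenyl and 4-methoxyphenyl stayed within it, whereas 1-methyl-1H-pyrazol-4-yl gives a clear rise, with a number 15 percentage points higher from compound 2 to compound 4 (beyond the scatter) and a number 17 percentage points higher from compound 1 to compound 4 (beyond the scatter) and a number 25 percentage points higher from compound 3 to compound 4 (beyond the scatter) as its three steps. Each step is modest and replaces a six-membered aromatic ring of carbon only with a five-membered aromatic ring with 2 hetero atoms. On these data alone, whether ring size, the ring nitrogens or the methyl group matters stays open, as does the effect of an amine, a carboxylic acid or a longer chain on that ring. No measurement here explains the rise.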